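Trifluoromethoxy-to-hydroxy step carried onto a second core

A few compounds are considered here, and "the series" means these few. Any claim that something is new, unique, unknown or untested is made for them only; others in the source may bear on it.

Measured compounds in a functional assay on SiHa cells (Homo sapiens) for inhibition, read by sulforhodamine B assay; on this read-out lower numbers stand for stronger inhibition of growth and higher numbers for weaker inhibition of growth:
- compound 1 `Oc1cccc2[nH]c(-c3ccc(-c4ccc(-c5ccc(OC(F)(F)F)cc5)cc4)cc3)nc12` gives 8410 nM
- compound 2 `Oc1ccc(-c2ccc(-c3ccc(-c4nc5c(O)cccc5[nH]4)cc3)cc2)cc1` gives 2410 nM
- compound 3 `Cc1ccc2[nH]c(-c3ccc(-c4ccc(-c5ccc(OC(F)(F)F)cc5)cc4)cc3)nc2c1` gives 28300 nM

Compound 1 and compound 2 differ by hydrogen in place of trifluoromethyl on an oxygen on an aromatic ring, and this change gave a 3.5-fold lower number from compound 1 to compound 2 (0.54 log units; beyond the scatter). Compound 3 sits on a different core; the two cores differ by 5-methyl-1H-benzimidazol-2-yl in place of 4-hydroxy-1H-benzimidazol-2-yl on an aromatic carbon, a change that brought a 3.4-fold higher number from compound 1 to compound 3 (0.53 log units; beyond the scatter). Compound 3 stands highest of the three numbers in this assay.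

Compound 4 `Cc1ccc2[nH]c(-c3ccc(-c4ccc(-c5ccc(O)cc5)cc4)cc3)nc2c1` is not yet measured. It differs from compound 3 by hydrogen in place of trifluoromethyl on an oxygen on an aromatic ring, and the place where the change sits is the same as in the step from compound 1 to compound 2, so it is the same change made on the other core. Among the measured compounds shown here, for compound 4 the expected step in this assay is a 3.3-fold lower number from compound 3 to compound 4 (0.52 log units; beyond the scatter), set beside the earlier step because the one observed example of this change gave a 3.5-fold lower number from compound 1 to compound 2 (0.54 log units; beyond the scatter) on the core of compound 1. For the measured compounds named here, whether the second core carries the change in the same way is not known from only one example, so the range is kept wide. Compound 4 is estimated at 8500 nM, with a range from 3000 nM to 25000 nM.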

Compound 4, concentration for 50% growth inhibition: 33500 nM
The estimate for compound 4 lay 3.9-fold (0.60 log units) below the measured number; the whole stated range lies below it.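

On the core of compound 3, the trifluoromethoxy to hydroxy change in this assay gave a 1.2-fold higher number from compound 3 to compound 4 (0.07 log units; within the scatter), so compound 3 and compound 4 cannot be told apart on this read-out. The effect of the change therefore differs between the two cores shown: the same change on two cores in this assay, a 3.5-fold lower number (0.54 log units; beyond the scatter) from compound 1 to compound 2 and a 1.2-fold higher number (0.07 log units; within the scatter) from compound 3 to compound 4, 4.1-fold (0.62 log units) apart, beyond the scatter of two such steps

Among the compounds shown here, a step seen on the core of compound 1 is thus no reliable guide to the core of compound 3, but with only one pair on each core, this does not show why the two differ or how the change would behave on any further core.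

As far as these compounds go, it remains open whether the 4-hydroxy or the 5-methyl group on the benzimidazole decides the outcome, as the two cores differ in both. Also open, from the compounds shown here alone, is whether an amine or a carboxylic acid in place of the hydroxy group would follow the pattern of the core of compound 1 or that of compound 3.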